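A few compounds are considered here, and "the series" means these few. Any claim that something is new, unique, unknown or untested is made for them only; others in the source may bear on it.

Three compounds of this series have numbers in a functional assay on L1210 cells (Mus musculus) for antiproliferative activity; a higher number here means a weaker inhibitor, a lower number a stronger inhibitor. Compound 1 `COc1cc(C(=O)c2sc(-c3ccc(F)cc3)cc2N)cc(OC)c1OC` gives 20 nM; compound 2 `COc1cc(C(=O)c2sc(-c3ccc(Cl)c(Cl)c3)cc2N)cc(OC)c1OC` gives 260 nM; compound 3 `CCOc1ccc(-c2cc(N)c(C(=O)c3cc(OC)c(OC)c(OC)c3)s2)cc1` gives 590 nM, the highest of the three and beyond the scatter from both others. The steps between them are a 13-fold higher number from compound 1 to compound 2 (1.11 log units; beyond the scatter), a 30-fold higher number from compound 1 to compound 3 (1.47 log units; beyond the scatter) and a 2.3-fold higher number from compound 2 to compound 3 (0.36 log units; beyond the scatter). Compound 4 `COc1cc(C(=O)c2sc(-c3cccc([N+](=O)[O-])c3)cc2N)cc(OC)c1OC` differs from compound 3 by 3-nitrophenyl in place of 4-ethoxyphenyl on an aromatic carbon. Among the compounds with values here, no nitrophenyl analogue has been measured. The closest guide is a 2.3-fold higher number from compound 2 to compound 3 (0.36 log units; beyond the scatter), where 4-ethoxyphenyl carried the higher number; a 30-fold higher number from compound 1 to compound 3 (1.47 log units; beyond the scatter) points the same way. Compound 4 is therefore expected to show a lower number, a 3.0-fold lower number from compound 3 to compound 4 (0.47 log units; beyond the scatter), the direction firmer than the size. The estimate for compound 4 is 200 nM, with a range of 40 nM to 1000 nM.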

Compound 4, half-maximal inhibitory concentration: 11 nM
For compound 4 the middle estimate is 18-fold (1.26 log units) above the measured one; the whole stated range lies above it.
By their numbers in this assay, from the lowest: compounds 4 and 1 (each within the scatter of the next); then compound 2; then compound 3.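

On the aromatic carbon next to the ring sulfur, 3-nitrophenyl gives a 54-fold lower number from compound 3 to compound 4 (1.73 log units; beyond the scatter) in this assay, although it has the same heavy-atom count as the 4-ethoxyphenyl it replaces. It also gives a 24-fold lower number from compound 2 to compound 4 (1.37 log units; beyond the scatter), while a 1.8-fold lower number from compound 1 to compound 4 (0.26 log units; within the scatter) shows that a low number here is not confined to 4-fluorophenyl. No measured evidence accounts for these steps.

Open, on these data alone, is whether an amine or a nitrile in place of the nitro group would keep the number low, and where an unsubstituted phenyl would stand.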